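Benzyl at the tetrazole carbon of compound 3

This account rests on a few compounds, and the source may have more. Where it says the series, first, only, none or still open, it means among the compounds named here.

Measured so far:
Compound 1 `Nc1ccc(-c2nnn(Cc3ccc(C(=O)NO)cc3)n2)cc1` gives 1 nM in an assay on Sf9 cells for inhibition of protein deacetylase HDAC6 (Homo sapiens), read by fluorescence; a higher number here means a weaker inhibitor, a lower number a stronger inhibitor.
Compound 2 `O=C(NO)c1ccc(Nc2nnc(-c3ccccc3)o2)cc1` gives 136 nM in this assay.
Compound 3 `O=C(NO)c1ccc(Cn2nnc(-c3ncccn3)n2)cc1` gives 7 nM in this assay.

Compound 3 holds the second highest of the three numbers in this assay; compound 1 is nearest with a lower number, and compound 2 is furthest with a higher number. Compound 4 `O=C(NO)c1ccc(Cn2nnc(Cc3ccccc3)n2)cc1` is still to be measured. It differs from compound 3 in one place: benzyl in place of pyrimidin-2-yl on an aromatic carbon.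

Within the data shown here, only one measured step touches this position: a 7.0-fold higher number from compound 1 to compound 3 (0.85 log units; beyond the scatter), a change on the same aromatic carbon between two ring nitrogen atoms. Among the measured compounds shown here, compound 2 has a different core and connection, so its value shows only that a number far above compound 3 is possible. For the measured compounds named here, the step to compound 4 puts a group of carbon only, on a benzyl, in that place; the data give no step of this kind. The expected change in this assay is small, within or just beyond the scatter, without a firm direction. Compound 4 is therefore estimated at 5 nM (range 1.5 nM to 20 nM), a step of a 1.4-fold lower number from compound 3 to compound 4 (0.15 log units; within the scatter).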

Compound 4, half-maximal inhibitory concentration: 52 nM
Estimate against measurement, compound 4: 10-fold (1.02 log units) below; the whole stated range lies below it.
By their numbers in this assay, from the lowest: compound 1; then compound 3; then compound 4; then compound 2.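

In this assay, this aromatic carbon of the five-membered ring does not accept every ring-bearing group equally: the change to benzyl gives a 7.4-fold higher number from compound 3 to compound 4 (0.87 log units; beyond the scatter), a clear step where the opening estimate allowed for little change. Replacing 4-aminophenyl with benzyl gives a 52-fold higher number from compound 1 to compound 4 (1.72 log units; beyond the scatter), the largest step yet at this place, and the three groups now order as 4-aminophenyl, pyrimidin-2-yl, benzyl, from the lowest number to the highest. Nothing measured here accounts for this order.

The compounds shown leave open whether the step from 4-aminophenyl to benzyl follows the added carbon link or the loss of the amine, since both change together. Plain phenyl or 4-aminobenzyl on the same carbon would separate the two.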